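Turning One Double Bond from E to Z

The compounds below may be only part of what the source reports. "The series", "measured", "known", "first", "only" and "open" are said of these compounds alone.

In a functional assay on P388 cells (Mus musculus) for inhibition (a higher number here means a weaker inhibitor, a lower number a stronger inhibitor), compound 2 `COc1cc(/C=C/c2c[nH]c3ccccc23)cc(OC)c1OC` gives 3230 nM as its half-maximal inhibitory concentration. Going by the values given here, compound 1 `COc1cc(/C=C\c2cn(C(C)=O)c3ccccc23)cc(OC)c1OC` gives 2850 nM in the same test, so the two values lie within the usual scatter of each other and compound 2 stands level with the only other measured compound. Compound 3 `COc1cc(/C=C\c2c[nH]c3ccccc23)cc(OC)c1OC` differs from compound 2 by the two compounds have the same atoms and bonds and differ only in configuration as drawn: 1 of 1 stereo elements differ; a double bond is drawn E in compound 2 and Z in compound 3 and by nothing else: a double bond is drawn E in compound 2 and Z in compound 3. The two compounds have the same atoms and bonds and differ only in configuration as drawn, yet they are separate molecules that can behave differently in a test. Among the compounds with values here, no measured pair shows this change on its own. Within the data shown here, compound 1 is the only measured compound with a Z double bond, and its value of 2850 nM gives no sign of a large gain. A small move toward a lower number, meaning somewhat stronger inhibition, is expected as a 1.8-fold lower number from compound 2 to compound 3 (0.25 log units; within the scatter) in this assay for this change. For compound 3 the estimated value is 1800 nM with an expected range from 400 nM to 6000 nM in this test.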

Compound 3, half-maximal inhibitory concentration: 3230 nM
Beside the measured number, compound 3's estimate is 1.8-fold (0.25 log units) below it; the range from low to high includes it.
By their numbers in this assay, from the lowest: compounds 1, 2 and 3 (each within the scatter of the next).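

Going by these compounds alone, the effect of this change can now be read on its own for the first time: in this assay, turning the double bond from E to Z gives no change at the digits printed from compound 2 to compound 3 (within the scatter). Compound 3 also links the other two compounds, since putting hydrogen in place of acetyl on the aromatic nitrogen gives a 1.1-fold higher number from compound 1 to compound 3 (0.05 log units; within the scatter), so neither single change separates the compounds in this test, and all three stand level. The first of these comparisons is an especially clean one, since no group enters or leaves and only the geometry of the drawn double bond is different: the fact that compounds 2 and 3 differ only in the configuration as drawn.

On these data alone, what remains open is whether the double bond's configuration would stay as unimportant with a different group on the aromatic nitrogen, such as a methyl group, a benzoyl group or a longer acyl chain. As far as these compounds go, it is also open whether an amine or a carboxylic acid elsewhere on the shared core would move the number beyond the scatter, and whether the E and Z forms would then still stand level.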